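Replacing a phenyl with a cyclohexylamino chain on a carbonyl

A few compounds are considered here, and "the series" means these few. Any claim that something is new, unique, unknown or untested is made for them only; others in the source may bear on it.

Compound 3 `O=C(c1ccccc1)N1N=C(c2cc3ccccc3oc2=O)CC1c1ccccc1` gives 5870 nM in a functional assay on PC-3 cells (Homo sapiens) for cytotoxicity, read by MTT assay, with a stated time of 48 h (on this read-out higher numbers stand for weaker inhibition and lower numbers for stronger inhibition), the lowest of the three numbers measured, though compound 2 `CC1=NN(C(=O)CN2CCCCC2)C(c2ccccc2O)C1` with 5890 nM sits within the scatter of it, while compound 1 `CC1=NN(C(=O)c2ccc(C)cc2)C(c2ccccc2O)C1` with 40600 nM is clearly higher. Compound 4 `O=C(CNC1CCCCC1)N1N=C(c2cc3ccccc3oc2=O)CC1c1ccccc1` has not been measured. Relative to compound 3 it carries (cyclohexylamino)methyl in place of phenyl on a carbonyl carbon. Among the compounds with values here, the one measured step of the same kind, a 6.9-fold lower number from compound 1 to compound 2 (0.84 log units; beyond the scatter), swapped an aromatic ring on a carbonyl carbon for an amine-bearing methyl and gave a modest lowering beyond the scatter. A lowering of similar or somewhat smaller size, a 3.9-fold lower number from compound 3 to compound 4 (0.59 log units; beyond the scatter), is therefore expected here, so compound 4 is estimated at 1500 nM, within 400 nM to 6000 nM.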

Compound 4, half-maximal inhibitory concentration: 48500 nM
Beside the measured number, compound 4's estimate is 32-fold (1.51 log units) below it, and the stated range ends below it.
By their numbers in this assay, from the lowest: compounds 3 and 2 (each within the scatter of the next); then compounds 1 and 4 (each within the scatter of the next).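

In this assay, (cyclohexylamino)methyl in place of phenyl on a carbonyl carbon produces an 8.3-fold higher number from compound 3 to compound 4 (0.92 log units; beyond the scatter) in this series, whereas the related swap with (piperidin-1-yl)methyl produced a 6.9-fold lower number from compound 1 to compound 2 (0.84 log units; beyond the scatter) on a different core. Replacing an aromatic ring at this position therefore does not move the number in one fixed direction, although both the amine and the core differ between these two steps. Nothing available explains this reversal. Going by these compounds, it remains open whether the direction follows the core or the amine. A morpholine or dimethylamino group on the same methyl could help to separate the two.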